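Thiophene in Place of Methoxynaphthyl on the Shared Core

The compounds below may be only part of what the source reports. "The series", "measured", "known", "first", "only" and "open" are said of these compounds alone.

Compound 2 `COc1ccc(C2C(C#N)=C(N)N(c3ccc(S(N)(=O)=O)cc3)C3=C2C(=O)CCC3)c2ccccc12` carries a 4-methoxynaphthalen-1-yl group on a saturated ring carbon of the shared core. In a functional assay on Ehrlich cells (Mus musculus) for antiproliferative activity, read by trypan blue exclusion, with a stated time of 2 h, tested at 100 ug/mL (a higher number here means a stronger effect of the compound at the concentration tested, a lower number a weaker effect), compound 2 gives 90%, the highest of the two numbers measured. Among the compounds with values here, its only neighbour is compound 1 `COc1ccccc1C1C(C#N)=C(N)N(c2ccc(S(N)(=O)=O)cc2)C2=C1C(=O)CCC2`, which in this assay gives 0%; the step of a number 90 percentage points higher from compound 1 to compound 2 (beyond the scatter) is the one measured change and it is large. Compound 3 `N#CC1=C(N)N(c2ccc(S(N)(=O)=O)cc2)C2=C(C(=O)CCC2)C1c1cccs1` is not yet measured. It differs from compound 2 in one place: thiophen-2-yl in place of 4-methoxynaphthalen-1-yl on a saturated ring carbon. Within the data shown here, the single measured step shows that exchanging the group on this saturated ring carbon can move the read-out strongly, but no step with thiophen-2-yl exists, so the direction for compound 3 is not fixed by the data. Compound 3 is therefore expected to fall by a number 50 percentage points lower from compound 2 to compound 3 (beyond the scatter), a wide and uncertain estimate. The expected value of compound 3 in this assay is 40%, between 5% and 85%.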

Compound 3, a percentage reported as activity, at one concentration (the size of the read-out at that concentration, not a potency): 100%
Beside the measured number, compound 3's estimate is 60 percentage points below it; the measured number lies above the stated range.
By their numbers in this assay, from the lowest: compound 1; then compounds 2 and 3 (each within the scatter of the next).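

In this assay, thiophen-2-yl in place of 4-methoxynaphthalen-1-yl gives a number 10 percentage points higher from compound 2 to compound 3 (within the scatter), so on this saturated ring carbon one five-membered aromatic ring with 5 heavy atoms reads the same as the larger 12-atom group with its two six-membered rings. In place of 2-methoxyphenyl, the same thiophen-2-yl gives a number 100 percentage points higher from compound 1 to compound 3 (beyond the scatter), which shows that a high read-out at this position needs neither a methoxy group nor a naphthalene, and leaves compound 1 as the only low one of the three. Nothing measured here explains why these groups read as they do.

The compounds shown leave open how a plain phenyl, a furan-2-yl or a phenyl carrying an amine or a carboxylic acid would read at this carbon. At a single concentration, they also leave open whether compound 2 and compound 3 differ in potency.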